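Benzyloxy for propyl on the alcohol side chain

The source may hold more compounds than are shown below. What is called first, only, known or untested is meant among the compounds shown, and "the series" means these compounds.

Measured so far:
compound 1 `CCCCC(O)Cn1cc(CN(C)CCCc2ccccc2)nn1` 37%
compound 2 `CCCCC(O)Cn1cc(CN(C)CCC(C)C)nn1` 47%

Going by the values given here, in an assay on nucleic acid for inhibition of Nucleic Acid, read by fluorescence, tested at 100 uM (a higher number here means more inhibition at the concentration tested (going by the name of the read-out), a lower number less inhibition), compound 1 gives 37% and compound 2 gives 47%; the two lie within the scatter of each other, and the only measured step, a number 10 percentage points higher from compound 1 to compound 2 (within the scatter), changes the amine side of the shared core. Compound 3 `CN(CCCc1ccccc1)Cc1cn(CC(O)COCc2ccccc2)nn1` differs from compound 1 at the other end: benzyloxy in place of propyl on a saturated chain carbon, two bonds along the chain from an oxygen on a saturated carbon. Among the compounds with values here, no measured step touches that place, so nothing points to a shift beyond the scatter. Compound 3 is therefore expected to give about 40%, between 20% and 60%, a step of a number 3 percentage points higher from compound 1 to compound 3 (within the scatter).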

Compound 3, a percentage reported as inhibition, at one concentration (the size of the read-out at that concentration, not a potency): 18%
Compound 3: the middle estimate sits 22 percentage points above what was measured; the measured number lies below the stated range.
By their numbers in this assay, from the lowest: compound 3; then compounds 1 and 2 (each within the scatter of the next).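

This position is not indifferent to what it carries: in this assay, benzyloxy in place of propyl gives a number 19 percentage points lower from compound 1 to compound 3 (beyond the scatter) on the alcohol side chain. The entering group brings an oxygen and an aromatic ring together, so this single step cannot separate their contributions. Nothing measured here explains the lower number.

Going by these compounds, whether methoxy or phenyl in that place would also lower the number remains open. So does whether benzyloxy would have the same effect on the amine side of compound 2.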